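Replacing an acid with a cyclopropyl amide on the shared core

This account rests on a few compounds, and the source may have more. Where it says the series, first, only, none or still open, it means among the compounds named here.

Measured so far:
- compound 1, `O=C(O)COc1ccc(NCc2cccc(Oc3ccccc3)c2)cc1`: 2040 nM
- compound 2, `Cc1nc(-c2ccc(C(F)(F)F)cc2)sc1CNc1ccc(CCC(=O)NC(C)C)cc1`: 100 nM

Both compounds were tested in a functional assay on CHO cells for agonist activity at Free fatty acid receptor 1 (Homo sapiens); on this read-out lower numbers stand for an effect already at smaller amounts and higher numbers for an effect only at larger amounts of compound. Compound 1 stands at the higher of the two numbers; compound 2 sits at a lower number, and the gap between the two lies beyond the usual scatter of repeated measurements.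

The next compound, compound 3 `CC(C)NC(=O)[C@H]1C[C@@H]1c1ccc(NCc2cccc(Oc3ccccc3)c2)cc1`, keeps the core of compound 1 and changes one group: 2-(isopropylcarbamoyl)cyclopropyl in place of carboxymethoxy on an aromatic carbon. Among the measured compounds shown here, no measured pair here shows this exact change, so its effect is open.

Two facts frame the expectation. Compound 1 gives 2040 nM. Compound 2, built differently but also carrying an amide ending in isopropyl, gives 100 nM. It seems reasonable to expect compound 3 to move toward the number of compound 2 without reaching it fully, because compound 2 gives 100 nM with a different core. The expected step is a 5.1-fold lower number from compound 1 to compound 3 (0.71 log units; beyond the scatter). Compound 3 is therefore estimated at 400 nM, with a likely range from 80 nM to 2000 nM.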

Compound 3, half-maximal effective concentration: 12.6 nM
Beside the measured number, compound 3's estimate is 32-fold (1.50 log units) above it, and the stated range ends above it.
By their numbers in this assay, from the lowest: compound 3; then compound 2; then compound 1.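

In this assay, the shared core shows a 160-fold lower number from compound 1 to compound 3 (2.21 log units; beyond the scatter) when 2-(isopropylcarbamoyl)cyclopropyl takes the place of carboxymethoxy on the aromatic carbon para to a large group. This position therefore accepts a group with more heavy atoms, a three-membered ring of carbon only and 2 defined stereocentres, and on this core carboxymethoxy is not needed for an effect at small amounts of compound. Nothing measured here explains the size of this step.

Because the entering group differs from carboxymethoxy in several features at once, the compounds shown do not separate what the cyclopropyl ring, the amide and the isopropyl end each contribute, nor whether the particular stereochemistry of compound 3 matters. A compound with a carboxylic acid on the same cyclopropyl ring, one with a methyl amide in place of the isopropyl amide, and the mirror-image form of compound 3 would each test one of these features on its own.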